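A few compounds are considered here, and "the series" means these few. Any claim that something is new, unique, unknown or untested is made for them only; others in the source may bear on it.

Measured so far in an ADME assay on MDBK cells (Bos taurus) for cytotoxicity; on this read-out higher numbers stand for lower toxicity in this test and lower numbers for higher toxicity in this test:
- compound 1 `CC(C)N(CCn1ccc2nc(-c3ccccc3)nc-2c1)C(C)C`: > 100000 nM (a limit)
- compound 2 `CC(C)=CCn1ccc2nc(-c3ccccc3)nc-2c1`: > 100000 nM (a limit)
- compound 3 `c1ccc(-c2nc3ccn(CC4CCCCC4)cc-3n2)cc1`: > 100000 nM (a limit)

Compound 3 stands at > 100000 nM, which is a limit of the assay and not a number. It has company there: the limit of > 100000 nM in this assay, at which 3 of the 3 values shown sit. The values therefore give no ranking among these compounds.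

Compound 4 `c1ccc(-c2nc3ccn(Cc4ccncc4)cc-3n2)cc1` has not yet been measured. It differs from compound 3 in one place: pyridin-4-yl in place of cyclohexyl on a saturated chain carbon bound to an aromatic nitrogen. Cyclohexylmethyl thus becomes (pyridin-4-yl)methyl, on an aromatic nitrogen of the shared core.

Three measured steps change the group at this same place: a step that the two limits leave unreadable from compound 1 to compound 2, a step that the two limits leave unreadable from compound 1 to compound 3 and a step that the two limits leave unreadable from compound 2 to compound 3. For the measured compounds named here, none has a readable size, and no measured compound carries a pyridin-4-yl group. Still, three different groups there all leave the read-out at the limit, so no step beyond the usual scatter is expected in this assay, in either direction. The expected change is a number no higher from compound 3 to compound 4 (the limit leaves the size open).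

Compound 4 is estimated at 100000 nM, with an expected range from 40000 nM to 150000 nM, and it may well report only the same limit.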

Compound 4, half-maximal cytotoxic concentration: > 100000 nM
Compound 4 was reported as a limit; the forecaster's own chance of this, stated with the estimate: 75%; the middle value lies on the limit itself.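

In this assay compound 4 gives > 100000 nM, which is a limit and not a number. The steps to compound 4 from compound 1, compound 2 and compound 3 cannot be read, and the four compounds cannot be ranked: the limit of > 100000 nM in this assay, at which 4 of the 4 values shown sit. The compounds shown leave open what actual cytotoxic concentration each of the four has, and whether changing this group alters it.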